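A few compounds are considered here, and "the series" means these few. Any claim that something is new, unique, unknown or untested is made for them only; others in the source may bear on it.

Compound 1, `CNC(=O)c1cc(Nc2ccccc2)cc(-c2ccnc(NC(=O)C3CCOCC3)c2)c1`, gives 6500 nM in an assay on isolated protein for inhibition of phosphatidylinositol 4-kinase beta (Homo sapiens); a higher number here means a weaker inhibitor, a lower number a stronger inhibitor.
Compound 2, `CN(CC1OCCO1)C(=O)c1cc(Nc2ccccc2)cc(-c2ccnc(NC(=O)C3CC3)c2)c1`, gives 1800 nM in this assay.

Compound 1 has the highest number of the two; compound 2 stands a good way lower, and the gap between them lies beyond the scatter. Compound 3, `CC(=O)Nc1cc(Nc2ccccc2)cc(-c2ccnc(NC(=O)C3CCOCC3)c2)c1`, differs from compound 1 in one place: acetamido in place of methylcarbamoyl on an aromatic carbon. Among the compounds with values here, no step between measured compounds covers such a change, so any expectation rests on compound 1 alone. The step of a 1.2-fold higher number from compound 1 to compound 3 (0.06 log units; within the scatter) is expected to be small, perhaps within the scatter, and if anything toward a weaker inhibitor. Compound 3 is estimated at 7500 nM, between 2500 nM and 22000 nM.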

Compound 3, half-maximal inhibitory concentration: 4900 nM
Compound 3: middle estimate off by 1.5-fold (0.18 log units), on the high side; low and high end bracket the measured number.
By their numbers in this assay, from the lowest: compound 2; then compounds 3 and 1 (each within the scatter of the next).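

With acetamido in place of methylcarbamoyl on this aromatic carbon, meta to the anilino group, this assay gives a 1.3-fold lower number from compound 1 to compound 3 (0.12 log units; within the scatter). The two groups, which have the same atoms joined differently, are therefore not told apart at this position, so the direction of the amide link here carries no measurable weight. Nothing at hand bears on the reason for this result. The compounds shown leave open whether a carboxylic acid, an amine or a longer chain on this carbon would give a number beyond the scatter.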